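The source may hold more compounds than are shown below. What is called first, only, known or untested is meant among the compounds shown, and "the series" means these compounds.

Two members of the series have been measured in a functional assay on QGY7701 cells (Homo sapiens) for cytotoxicity, read by MTT assay, with a stated time of 24 h; on this read-out lower numbers stand for stronger inhibition and higher numbers for weaker inhibition. Compound 1 `C=CC1=C(C(=O)NCCCCC)C(c2ccc(OC)cc2)OC1` returns only the assay limit, > 100000 nM, in this assay. Compound 2 `C=CC1=C(C(=O)NCc2ccccc2)C(c2ccc(Cl)c(Cl)c2)OC1` likewise returns only the limit, > 100000 nM, in this assay. Within the data shown here, both results sit at the same limit (the limit of > 100000 nM in this assay, at which 2 of the 2 values shown sit), so no step between measured compounds can be computed, and compound 2 stands on the limit without a number of its own. Compound 3 `C=CC1=C(C(=O)NCCCCC)C(c2ccc(Cl)c(Cl)c2)OC1` is not yet measured and differs from compound 2 in one place: butyl in place of phenyl on a saturated chain carbon bound to an amide-type nitrogen. Among the measured compounds shown here, no measured step speaks to this change. Since compound 2 sits at the limit (the limit of > 100000 nM in this assay, at which 2 of the 2 values shown sit), the step to compound 3 in this assay is expected to be none beyond the scatter, set down as a step that the limit leaves unreadable from compound 2 to compound 3. The estimate for compound 3 is 150000 nM, with a range from 50000 nM to 500000 nM, most likely reported again as a limit rather than a number.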

Compound 3, half-maximal inhibitory concentration: > 100000 nM
Compound 3: only a limit was reported (the forecaster's own chance of this, stated with the estimate: 85%); the middle value does not contradict the limit.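

Compound 2 and compound 3 both return only a limit, so the step between them cannot be read: the limit of > 100000 nM in this assay, at which 3 of the 3 values shown sit. The compounds shown leave open which change to the shared core, if any, would give a measurable number in this assay rather than a limit.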